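Lipophilicity on the Path from Compound 3 to Compound 4

This account rests on a few compounds, and the source may have more. Where it says the series, first, only, none or still open, it means among the compounds named here.

Of the compounds shown here, three built on a shared core have been measured in a physicochemical assay for lipophilicity, read by HPLC, in phosphate buffer, measured as chromatographic lipophilicity, at pH 7.4; on this read-out higher numbers stand for higher lipophilicity and lower numbers for lower lipophilicity. Compound 1 `Cc1cc(C)cc(NC(=O)COc2cc(C)nc3ccccc23)c1` gives 5.39 in this assay. Compound 2 `CCC(Oc1cc(C)nc2ccc(OC)cc12)C(=O)Nc1cc(C)cc(C)c1` gives 6.28. Compound 3 `COc1ccc2nc(C)cc(OCC(=O)Nc3cc(C)ccc3OC)c2c1` gives 5.65, the second highest of the three numbers; its nearest neighbour is compound 1, whose number lies within the scatter of it, and its furthest is compound 2, whose number lies beyond the scatter and higher.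

Compound 4 `COc1ccc2nc(C)cc(OCC(=O)Nc3ccncn3)c2c1` has not yet been measured. It differs from compound 3 in a single place: pyrimidin-4-yl in place of 2-methoxy-5-methylphenyl on an amide-type nitrogen. For the measured compounds named here, no step between two measured compounds that differ in one place is available, so the expectation rests on the structures alone. Swapping a carbon-only aromatic ring for a six-membered aromatic ring with two hetero atoms on the amide-type nitrogen is expected to lower the number in this assay by a step well beyond the scatter, estimated as a number 1.85 log units lower from compound 3 to compound 4 (beyond the scatter). Compound 4 is therefore expected to give about 3.8, with a likely range from 3 to 4.6.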

Compound 4, distribution coefficient: 2.53
Compound 4: the middle estimate sits 1.27 log units above what was measured; the measured number lies below the stated range.
By their numbers in this assay, from the lowest: compound 4; then compounds 1 and 3 (each within the scatter of the next); then compound 2.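

In this assay, for the compounds shown here, pyrimidin-4-yl in place of 2-methoxy-5-methylphenyl on an amide-type nitrogen gives a number 3.12 log units lower from compound 3 to compound 4 (beyond the scatter), the first single-place step. It shows that the number can move by a large amount through a change at this one position alone, with the rest of the molecule held the same. Nothing measured here explains why the step is so large.

This single swap changes several things at once: the ring's atoms, the methoxy and methyl groups, and the number of heavy atoms and hydrogen-bond acceptors, so the compounds shown leave open how much of the step belongs to each. A plain phenyl group or a pyridinyl group on the same nitrogen would help to divide the step between these parts.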